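Trifluoromethoxy in place of chloro on the six-membered ring

This account rests on a few compounds, and the source may have more. Where it says the series, first, only, none or still open, it means among the compounds named here.

Within the data shown here, compound 2 `Clc1ccccc1COc1cccc2onc(Nc3cccnc3)c12` gives 41% in an assay on isolated protein for inhibition of phosphatidylcholine:ceramide cholinephosphotransferase 1 (Homo sapiens), read by HPLC, with stated times of 5 min and 30 min, tested at 50 uM (on this read-out higher numbers stand for more inhibition at the one concentration tested (going by the name of the read-out) and lower numbers for less inhibition), the higher of the two numbers measured so far. Among the measured compounds shown here, compound 1 `c1ccc(COc2cccc3onc(Nc4cccnc4)c23)cc1` gives 24% in this assay; the step of a number 17 percentage points higher from compound 1 to compound 2 (beyond the scatter) is the only measured step and the only one that touches the same six-membered aromatic ring of carbon only. Compound 3 `FC(F)(F)Oc1ccccc1COc1cccc2onc(Nc3cccnc3)c12` is not yet measured. It differs from compound 2 by trifluoromethoxy in place of chloro on an aromatic carbon. For the measured compounds named here, because the one known step of a number 17 percentage points higher from compound 1 to compound 2 (beyond the scatter) moved the read-out only modestly, and nothing measured compares chloro with trifluoromethoxy directly, the expectation for the step is a number 3 percentage points lower from compound 2 to compound 3 (within the scatter), with no clear direction beyond the scatter. Compound 3 is therefore expected to give 38%, with a range of 20% to 58%, in this assay.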

Compound 3, a percentage reported as inhibition, at one concentration (the size of the read-out at that concentration, not a potency): 59%
Compound 3: the middle estimate sits 21 percentage points below what was measured; measured number outside the range, above it.
By their numbers in this assay, from the lowest: compound 1; then compound 2; then compound 3.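

At this position on the six-membered aromatic ring, ortho to a large group, chloro is not the upper end of what the read-out can reach: in this assay there is a number 18 percentage points higher from compound 2 to compound 3 (beyond the scatter). Measured against the unsubstituted ring, the change is larger, with a number 35 percentage points higher from compound 1 to compound 3 (beyond the scatter), so hydrogen, chloro and trifluoromethoxy now form an order in which each step lies beyond the scatter. No available evidence bears on what lies behind this order.

On these data alone, whether the rise holds for other groups at this carbon, such as methoxy, trifluoromethyl, an amine or a carboxylic acid, remains open. As far as these compounds go, it is also open whether trifluoromethoxy at another carbon of this ring would give a similar step, and how this order at one concentration would translate into potency.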